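The source may hold more compounds than are shown below. What is called first, only, known or untested is meant among the compounds shown, and "the series" means these compounds.

Measured compounds:
Compound 1, `CCCCNS(=O)(=O)c1ccc(Nc2ncc3c(n2)N(C2CCCC2)[C@H](CC)C(=O)N3C)cc1` — 451 nM
Compound 2, `CCCNS(=O)(=O)c1ccc(Nc2ncc3c(n2)N(C2CCCC2)[C@H](CC)C(=O)N3C)cc1` — 459 nM
Compound 3, `CCCNC(=O)c1ccc2c(ccn2-c2ncc3c(n2)N(C2CCCC2)[C@H](CC)C(=O)N3C)c1` — 238 nM

All three were tested in a functional assay on HeLa cells (Homo sapiens) for antiproliferative activity, read by CCK-8 assay, with a stated time of 72 h; a lower number here means a stronger inhibitor of growth, a higher number a weaker inhibitor of growth. Compound 2 and compound 1 share one core and differ by methyl in place of hydrogen on a saturated chain carbon, three bonds along the chain from a sulfonamide nitrogen; that change gave a 1.0-fold lower number from compound 2 to compound 1 (0.01 log units; within the scatter). Compound 3 is built on another core; the difference between the two cores is not broken down here. Compound 4, `CCCCNC(=O)c1ccc2c(ccn2-c2ncc3c(n2)N(C2CCCC2)[C@H](CC)C(=O)N3C)c1`, has not been measured. It differs from compound 3 by methyl in place of hydrogen on a saturated chain carbon, three bonds along the chain from an amide-type nitrogen. This is the same kind of change as that between compound 2 and compound 1, though here the chain is counted from an amide-type nitrogen rather than a sulfonamide nitrogen. Because a 1.0-fold lower number from compound 2 to compound 1 (0.01 log units; within the scatter) lay within the scatter, compound 4 is expected to show only a 1.0-fold lower number from compound 3 to compound 4 (0.01 log units; within the scatter). For compound 4 the estimate in this assay is 235 nM, expected between 120 nM and 470 nM.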

Compound 4, concentration for 50% growth inhibition: 346 nM
The estimate for compound 4 lay 1.5-fold (0.17 log units) below the measured number, within the range that was stated.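

In this assay, the change from propyl to butyl on the amide-type nitrogen gave a 1.5-fold higher number from compound 3 to compound 4 (0.16 log units; within the scatter). Set beside the matching change on the sulfonamide core, the step carried from one core to the other with no gap that can be told from scatter: the same change on two cores in this assay, a 1.0-fold lower number (0.01 log units; within the scatter) from compound 2 to compound 1 and a 1.5-fold higher number (0.16 log units; within the scatter) from compound 3 to compound 4, 1.5-fold (0.17 log units) apart, within the scatter of two such steps. Among the compounds shown here, this shows only that the step stayed small in these two pairs; it does not show that the two cores respond alike to larger changes, or that the change would stay small on any other core.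

As far as these compounds go, whether a longer chain, a branched chain, or a chain carrying an amine or a carboxylic acid would stay equally small on either core remains open.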